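A few compounds are considered here, and "the series" means these few. Any claim that something is new, unique, unknown or untested is made for them only; others in the source may bear on it.

Compound 1 `O=c1[nH]cc(S(=O)(=O)Nc2cccc(-c3cn(-c4ccccc4)nn3)c2)c(=O)[nH]1` in an ADME assay on GES1 cells (Homo sapiens) for cytotoxicity, read by MTT assay, with a stated time of 24 h (on this read-out lower numbers stand for higher toxicity in this test and higher numbers for lower toxicity in this test), gives 22500 nM. Compound 2 `O=c1[nH]cc(S(=O)(=O)Nc2cccc(-c3cn(-c4ccc(F)cc4)nn3)c2)c(=O)[nH]1` in this assay is reported as "not toxic" (no number reported), so no single number places it on the scale, and its standing relative to compound 1 cannot be read from the figures. Compound 3 `O=c1[nH]cc(S(=O)(=O)Nc2cccc(-c3cn(-c4cccc(Cl)c4)nn3)c2)c(=O)[nH]1` differs from compound 2 by 3-chlorophenyl in place of 4-fluorophenyl on an aromatic nitrogen. Going by the values given here, no measured step of this kind exists, so the size of the change in this assay is unknown; a shift no larger than the usual scatter, in either direction, seems the most likely outcome. Compound 3 is expected to give 40000 nM, between 15000 nM and 120000 nM.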

Compound 3, half-maximal cytotoxic concentration: 26200 nM
Compound 3: middle estimate off by 1.5-fold (0.18 log units), on the high side; low and high end bracket the measured number.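

In this assay, chloro in place of hydrogen on an aromatic carbon of the phenyl group gives a 1.2-fold higher number from compound 1 to compound 3 (0.07 log units; within the scatter), so at this position 3-chlorophenyl and unsubstituted phenyl cannot be told apart. The step between compound 2 and compound 3 cannot be read, since compound 2 has no number. Nothing available explains this result.

From the compounds shown here alone, it remains open whether an amine or a carboxylic acid on this phenyl group would shift the read-out. Also open, going by these compounds, is what a longer chain in place of the phenyl group on the aromatic nitrogen would do.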